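This account rests on a few compounds, and the source may have more. Where it says the series, first, only, none or still open, it means among the compounds named here.

Measured in a functional assay on COLO 205 cells (Homo sapiens) for cytotoxicity, read by MTT assay, with a stated time of 48 h; a higher number here means a weaker inhibitor, a lower number a stronger inhibitor:
- compound 1 `CCOC(=O)C1=C(C)NC(=S)NC1c1ccc(OCCCOc2ccc(C3NC(=S)NC(C)=C3C(=O)OCC)cc2OC)c(OC)c1`: 49 ug/mL
- compound 2 `COC(=O)[C@@H]1CCCN1C(=O)C1=C(C)NC(=S)NC1c1ccc(OC/C=C\COc2ccc(C3NC(=S)NC(C)=C3C(=O)N3CCC[C@H]3C(=O)OC)cc2OC)c(OC)c1`: > 200 ug/mL

Compound 1 has a true number in this assay. Compound 2 has none, and its reading of > 200 ug/mL is a limit of the assay, not a number.

The next compound to be tested is compound 3 `COC(=O)[C@@H]1CCCN1C(=O)C1=C(C)NC(=S)NC1c1ccc(OC/C=C/COc2ccc(C3NC(=S)NC(C)=C3C(=O)N3CCC[C@H]3C(=O)OC)cc2OC)c(OC)c1`. The two compounds have the same atoms and bonds, and they differ only in shape at one place: the two compounds have the same atoms and bonds; at least one stereo element is drawn with a configuration in one of them and without one in the other: 1 of 5 stereo elements differ; a double bond is drawn Z in compound 2 and E in compound 3. A double bond is drawn Z in compound 2 and E in compound 3.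

Among the measured compounds shown here, no measured pair shows what such a switch does in this assay, so no step beyond the usual scatter is expected, in either direction. Another limit reading is quite possible.

The expected change is a number no higher from compound 2 to compound 3 (the limit leaves the size open).

Compound 3 is estimated at 200 ug/mL, with an expected range from 80 ug/mL to 400 ug/mL.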

Compound 3, half-maximal inhibitory concentration: 69 ug/mL
Estimate against measurement, compound 3: 2.9-fold (0.46 log units) above, outside the stated range (below it).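

In this assay, a switch of the double bond from Z to E, with no atom added or removed, is enough to give an at least 2.8-fold lower number from compound 2 to compound 3 (0.46 log units; beyond the scatter). This is the first sign among these compounds that shape alone at this one place can shift the number beyond the usual scatter. Going by these compounds, the full size of the step stays open, since one end of it is not a number: the limit of > 200 ug/mL in this assay, at which 1 of the 3 values shown sits.

On these data alone, whether a longer chain carrying the E double bond, or a carboxylic acid in place of the methyl ester, would move the number further in either direction stays open. How firmly this step can be read also depends on how the two structures are drawn, and the caution here is: the fact that one of compounds 2 and 3 is drawn with a defined configuration and the other without, at the place where they differ.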